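This account rests on a few compounds, and the source may have more. Where it says the series, first, only, none or still open, it means among the compounds named here.

In an ADME assay on HaCaT cells (Homo sapiens) for antiproliferative activity, read by MTT assay, with a stated time of 48 h (a lower number here means a stronger inhibitor, a higher number a weaker inhibitor), compound 1 `O=C(/C=C\Nc1ccc(F)cc1)c1cn(-c2ccccc2)nc1-c1ccccc1` gives 34200 nM. Compound 2 `O=C(/C=C\Nc1ccc(Cl)cc1)c1cn(-c2ccccc2)nc1-c1ccccc1` gives 28400 nM in this assay. Within the data shown here, the only step so far, a 1.2-fold lower number from compound 1 to compound 2 (0.08 log units; within the scatter), exchanges one halogen for another at the same position, and it lies within the scatter. Compound 2 therefore carries the lower of the two numbers, but the two compounds cannot be told apart on the evidence shown.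

Compound 3 `O=C(/C=C\Nc1ccc(C(F)(F)F)cc1)c1cn(-c2ccccc2)nc1-c1ccccc1` differs from compound 2 in one place: trifluoromethyl in place of chloro on an aromatic carbon. Among the measured compounds shown here, the single measured step bears directly on this change, since it replaced a group at the very same aromatic carbon, and it was too small to stand out of the scatter. On that basis a step of about a 1.1-fold lower number from compound 2 to compound 3 (0.06 log units; within the scatter) from compound 2 to compound 3 in this assay is expected, with no direction that can be claimed beyond the scatter. Compound 3 is therefore estimated at 25000 nM in this assay, with a range of 10000 nM to 60000 nM.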

Compound 3, half-maximal inhibitory concentration: > 50000 nM
Compound 3: a limit, no number (the forecaster's own chance of this, stated with the estimate: 15%); middle value at least 2.0-fold (0.30 log units) away from the limit.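

In this assay, among these compounds, compound 3 returns a limit and not a number, the first such reading at this position: the limit of > 50000 nM in this assay, at which 1 of the 3 values shown sits. Trifluoromethyl in place of chloro gives an at least 1.7-fold higher number from compound 2 to compound 3 (0.24 log units; that floor lies within the scatter), and trifluoromethyl in place of fluoro gives an at least 1.4-fold higher number from compound 1 to compound 3 (0.16 log units; that floor lies within the scatter). These steps are floors and not measured sizes, so this change may or may not separate compound 3 from the two halogen compounds, and the true size of either step cannot be read.

On these data alone, what an amine, a carboxylic acid or a methoxy group on this same aromatic carbon would give in this assay remains open. Also open, as far as these compounds go, is whether any change elsewhere on the shared core, such as on either of its unsubstituted phenyl groups, would move the number beyond the scatter.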